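A few compounds are considered here, and "the series" means these few. Any claim that something is new, unique, unknown or untested is made for them only; others in the source may bear on it.

Measured so far:
compound 1 `CC(C)C1c2ncn(Cc3ccccc3)c2NC(=O)N1Cc1ccccc1`: 51%
compound 2 `O=c1nc2c(ncn2Cc2ccccc2)c(C#CC2CC2)n1Cc1ccccc1`: 97%

Both compounds were tested in a functional assay on K562 cells (Homo sapiens) for cytotoxicity, read by thymidine incorporation, with a stated time of 48 h, tested at 10 ug/mL; on this read-out higher numbers stand for more inhibition at the one concentration tested (going by the name of the read-out) and lower numbers for less inhibition. Compound 2 gives 97%, the higher of the two numbers. Compound 1 gives 51%, which lies far below compound 2, well beyond the usual scatter of such measurements. Among the compounds with values here, no single-change step between these two has been worked out, so their two values are simply compared side by side.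

Compound 3 `CC(C)c1c2ncn(Cc3ccccc3)c2nc(=O)n1Cc1ccccc1` is the next compound to be measured. It differs from compound 2 at one place: isopropyl in place of 2-cyclopropylethynyl on an aromatic carbon. In compound 3 the isopropyl group sits on an aromatic carbon of a six-membered aromatic ring, the same kind of group that compound 1 carries on its non-aromatic core. Given that compound 1 gives 51% while compound 2 gives 97%, a downward step is expected, likely beyond the scatter. The step from compound 2 to compound 3 is estimated at a number 32 percentage points lower from compound 2 to compound 3 (beyond the scatter). Compound 3 is expected to give about 65%, within a range from 35% to 90%.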

Compound 3, a percentage reported as inhibition, at one concentration (the size of the read-out at that concentration, not a potency): 18%
Estimate against measurement, compound 3: 47 percentage points above; measured number outside the range, below it.
By their numbers in this assay, from the lowest: compound 3; then compound 1; then compound 2.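

In this assay, putting isopropyl in place of 2-cyclopropylethynyl on this aromatic carbon gives a number 79 percentage points lower from compound 2 to compound 3 (beyond the scatter), so the read-out is highly sensitive to the group at this position on the shared core. Both groups are made of carbon only, with no hydrogen-bond donors or acceptors and no net charge, so a large step can arise here without any change in those counts. Nothing measured here explains why the number falls so far.

As far as these compounds go, it remains open which part of 2-cyclopropylethynyl the higher number depends on: its triple bond, its three-membered ring or its larger count of heavy atoms. From the compounds shown here alone, how a plain ethynyl group, a longer alkyne chain or an amine on this same aromatic carbon would behave also remains open.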